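The source may hold more compounds than are shown below. What is called first, only, known or untested is meant among the compounds shown, and "the series" means these compounds.

Measured compounds:
- compound 1 `NS(=O)(=O)c1ccc(-c2nc(C(c3ccc(F)cc3)c3ccc(F)cc3)sc2CC(=O)O)cc1`: 1500 nM
- compound 2 `COc1ccc(C(c2ccccc2)c2nc(-c3ccc(Cl)cc3)c(CC(=O)O)s2)cc1`: 8.4 nM
- compound 3 `O=C(O)Cc1sc(NCc2ccccc2)nc1-c1ccc(Cl)cc1`: 440 nM

All three values come from an in vitro assay on HEK385-7 cells for displacement of a labelled ligand from prostaglandin D2 receptor 2 (Homo sapiens); a lower number here means a stronger inhibitor, a higher number a weaker inhibitor. Compound 1 gives the highest number of the three. The nearest is compound 3, whose number is lower by an amount beyond the usual scatter; the furthest is compound 2, whose number is far lower still. No two of these compounds differ in only one place, so the values speak only as a whole and no single change can be read off from them.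

Compound 4 `O=C(O)Cc1sc(C(c2ccc(F)cc2)c2ccc(F)cc2)nc1-c1ccnc(O)c1` has not been measured. Its change from compound 1 is 2-hydroxypyridin-4-yl in place of 4-sulfamoylphenyl on an aromatic carbon. For the measured compounds named here, no pair of measured compounds reports a step for this change, so there is no direct precedent in this assay. Given that compound 1 stands at the weak end of the three numbers, the expectation for compound 4 is a modest move toward lower numbers, though one that could well fall within the scatter; the expected step is a 2.1-fold lower number from compound 1 to compound 4 (0.33 log units; beyond the scatter). For compound 4 the estimate in this assay is 700 nM, with a range of 150 nM to 3000 nM.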

Compound 4, half-maximal inhibitory concentration: 68 nM
Compound 4: the middle estimate sits 10-fold (1.01 log units) above what was measured, and the stated range ends above it.
By their numbers in this assay, from the lowest: compound 2; then compound 4; then compound 3; then compound 1.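

In this assay, for the compounds shown here, the aromatic carbon next to the ring nitrogen and next to the ring atom that bears a carboxymethyl group proves sensitive to its substituent: 2-hydroxypyridin-4-yl in place of 4-sulfamoylphenyl gives a 22-fold lower number from compound 1 to compound 4 (1.34 log units; beyond the scatter), a large step and the only single-place comparison. The entering group has fewer heavy atoms, yet the two groups have the same counts of hydrogen-bond donors and acceptors, so those counts do not separate them. No supporting measurement bears on why the step is this large.

Open, from the compounds shown here alone, is how a pyridin-4-yl without the hydroxyl, or a 2-aminopyridin-4-yl, would compare at this position with the rest of compound 4 kept. Also open, going by these compounds, is whether 2-hydroxypyridin-4-yl in place of 4-chlorophenyl would give a like step in compound 2 and compound 3.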